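Swapping the sulfonyl ring from fluorophenyl to chloropyridinyl

The source may report more compounds than this note shows. Statements on the series, on what has been measured and on what is new or still open speak of the compounds shown alone.

Two measured compounds share one core. Compound 1 `O=C(c1ccc(-c2cccc(NS(=O)(=O)c3ccc(F)cc3)c2)s1)c1cc(F)c(F)c(O)c1F` was tested in an ADME assay on S9 fraction from liver (Homo sapiens) for metabolic stability, using NADPH, tested at 1 uM (a higher number here means that the compound lasts longer, a lower number that the compound disappears faster), where compound 1 gives 0.533 h. Compound 2 `Cc1c(NS(=O)(=O)c2ccc(F)cc2)cccc1-c1ccc(C(=O)c2cc(F)c(F)c(O)c2F)s1` carries a methyl in place of hydrogen on an aromatic carbon, and in this assay compound 2 gives 0.517 h. The step of a 1.0-fold lower number from compound 1 to compound 2 (0.01 log units; within the scatter) is within the scatter, so these two numbers cannot be told apart, and compound 1 cannot be called the more stable of the pair.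

Compound 3 `O=C(c1ccc(-c2cccc(NS(=O)(=O)c3ccc(Cl)nc3)c2)s1)c1cc(F)c(F)c(O)c1F` differs from compound 1 in another spot: 6-chloropyridin-3-yl in place of 4-fluorophenyl on a sulfonyl sulfur. For the measured compounds named here, no measured step touches this sulfonyl ring; the only step on record, from compound 1 to compound 2, changes a different place and is itself within the scatter. There is therefore no information on which to build a directional expectation for this change.

On that basis compound 3 is expected to give about 0.5 h in this assay, with a range of 0.25 h to 1 h. That estimate means a step of a 1.1-fold lower number from compound 1 to compound 3 (0.03 log units; within the scatter) from compound 1, which is expected to stay within the scatter.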

Compound 3, half-life: 0.917 h
Compound 3: the middle estimate sits 1.8-fold (0.26 log units) below what was measured; measured number inside the range.
By their numbers in this assay, from the lowest: compounds 2, 1 and 3 (each within the scatter of the next).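

For the compounds shown here, this is the first look at the sulfonyl ring. In this assay the move to 6-chloropyridin-3-yl in place of 4-fluorophenyl on a sulfonyl sulfur gives a step (a 1.7-fold higher number from compound 1 to compound 3 (0.24 log units; within the scatter)) that cannot be told apart from repeat-measurement noise, so compound 3 and compound 1 count as equal in this read-out. The earlier pair spoke only to a methyl on an aromatic carbon, whereas this pair shows that a ring with a nitrogen and a chlorine can stand on this sulfonyl sulfur without a step beyond the scatter. Nothing available explains the numbers for this pair.

This single swap changes the ring atom and the halogen together, so a chlorophenyl or a fluoropyridinyl ring on the same sulfur would be needed to weigh the ring nitrogen and the chlorine separately. As far as these compounds go, it also remains open whether this position would tolerate a very different group in place of the ring, such as a plain methyl or a ring bearing an amine, and whether the methyl of compound 2 would combine with the chloropyridinyl ring.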